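This account rests on a few compounds, and the source may have more. Where it says the series, first, only, none or still open, it means among the compounds named here.

Three compounds have been measured in a functional assay on HT-29 cells (Homo sapiens) for antiproliferative activity, read by CellTiter-Glo, with a stated time of 72 h; a lower number here means a stronger inhibitor, a higher number a weaker inhibitor:

compound 1 `Cc1cc(C)c(S(=O)(=O)N2CCC(N3CCC(C)CC3)CC2)c(C)c1` gives 0.9 nM
compound 2 `Cc1cc(C)c(S(=O)(=O)N2CCC(N3CCC(C(C)C)CC3)CC2)c(C)c1` gives 0.2 nM
compound 3 `C#CCCC(=O)CC1CCN(C2CCN(S(=O)(=O)c3c(C)cc(C)cc3C)CC2)CC1` gives 2.1 nM

Compound 3 stands highest of the three; the step of a 2.3-fold higher number from compound 1 to compound 3 (0.37 log units; beyond the scatter) is modest, the step of an 11-fold higher number from compound 2 to compound 3 (1.02 log units; beyond the scatter) large. Compound 4 `Cc1cc(C)c(S(=O)(=O)N2CCC(N3CCC(Cc4ccccc4)CC3)CC2)c(C)c1` differs from compound 3 by phenyl in place of (but-3-yn-1-yl)carbonyl on a saturated chain carbon bound to a saturated ring carbon. Within the data shown here, two measured steps bear on this: the step of a 2.3-fold higher number from compound 1 to compound 3 (0.37 log units; beyond the scatter) shows that the chain with the carbonyl raised the number, and the step of a 4.5-fold lower number from compound 1 to compound 2 (0.65 log units; beyond the scatter) shows that a larger saturated group on the ring carbon lowered it. A benzyl group is therefore expected to bring the number back down, with a step of a 4.2-fold lower number from compound 3 to compound 4 (0.62 log units; beyond the scatter) in this assay. Compound 4 is estimated at 0.5 nM, in the range 0.15 nM to 2 nM.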

Compound 4, half-maximal inhibitory concentration: 3 nM
Compound 4: middle estimate off by 6.0-fold (0.78 log units), on the low side; the whole stated range lies below it.
By their numbers in this assay, from the lowest: compound 2; then compound 1; then compounds 3 and 4 (each within the scatter of the next).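

In this assay, phenyl and (but-3-yn-1-yl)carbonyl on a saturated chain carbon bound to a saturated ring carbon cannot be told apart (a 1.4-fold higher number from compound 3 to compound 4 (0.15 log units; within the scatter)). The fall in the number from methyl to isopropyl does not carry over to benzyl, which stands on the other side of methyl (a 3.3-fold higher number from compound 1 to compound 4 (0.52 log units; beyond the scatter)) and far from isopropyl (a 15-fold higher number from compound 2 to compound 4 (1.18 log units; beyond the scatter)). Nothing available explains this. The compounds shown leave open whether tert-butyl or cyclohexylmethyl on the ring carbon would give a number nearer that of isopropyl or that of benzyl, and whether an amine on the chain would differ from phenyl.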